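The source may hold more compounds than are shown below. What is called first, only, known or untested is meant among the compounds shown, and "the series" means these compounds.

Measured compounds:
compound 1 `CCCC(=O)Oc1ccc2oc(/C=C/[S+](C)[O-])cc(=O)c2c1` — 2200 nM
compound 2 `C[S+]([O-])/C=C/c1cc(=O)c2cc(O)ccc2o1` — 10500 nM

Compound 2 holds the highest of the two numbers in a functional assay on A549 cells (Homo sapiens) for cytotoxicity, with a stated time of 48 h; a lower number here means a stronger inhibitor, a higher number a weaker inhibitor; its nearest neighbour is compound 1, separated by a 4.8-fold higher number from compound 1 to compound 2 (0.68 log units; beyond the scatter). Compound 3 `C[S+]([O-])/C=C/c1cc(=O)c2cc(C#N)ccc2o1` is derived from compound 2 by cyano in place of hydroxy on an aromatic carbon. Among the compounds with values here, the only measured step, a 4.8-fold higher number from compound 1 to compound 2 (0.68 log units; beyond the scatter), touches the hydroxy that now leaves, but it exchanges hydrogen for propylcarbonyl rather than introducing a cyano, so it gives no direct parallel; it only shows that changing this group can move the number modestly in either direction. With a single step of this kind as guidance, compound 3 is expected to land near compound 2, with a 1.5-fold lower number from compound 2 to compound 3 (0.18 log units; within the scatter) as the estimated step and a wide allowance for either outcome. Compound 3 is therefore expected to give about 7000 nM in this assay, within a range of 2000 nM to 25000 nM.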

Compound 3, half-maximal inhibitory concentration: > 10000 nM
Compound 3: a limit, no number; the forecaster's own chance of this, stated with the estimate: 10%; middle value at least 1.4-fold (0.15 log units) from the limit.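

In this assay compound 3 gives > 10000 nM, which is a limit of the assay and not a number, so the change from hydroxy to cyano cannot be read as a step. Cyano in place of (propylcarbonyl)oxy on an aromatic carbon, however, can be read, as an at least 4.5-fold higher number from compound 1 to compound 3 (0.65 log units; beyond the scatter). This position therefore now has two replacements for the (propylcarbonyl)oxy group, hydroxy and cyano, and both leave the number higher, beyond the scatter, so among the three compounds shown compound 1 remains the strongest inhibitor.

On these data alone, how compound 3 truly stands against compound 2 stays open, since only a limit is available for it. The compounds shown also leave open whether an amine, a methoxy group or an ester with a longer chain at this position would match or better compound 1.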